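Replacing a Fluoropyridyl Sulfonamide with an Ethylphenyl Group

The compounds below may be only part of what the source reports. "The series", "measured", "known", "first", "only" and "open" are said of these compounds alone.

Compound 1 `CC1CCN(C2CCN(S(=O)(=O)c3cccnc3F)CC2)CC1` stands apart from the other two measured compounds. In a functional assay on DLD-1 cells (Homo sapiens) for antiproliferative activity, read by CellTiter-Glo, with a stated time of 72 h (on this read-out higher numbers stand for weaker inhibition and lower numbers for stronger inhibition), compound 1 reached only a limit of the assay, > 5000 nM, so no number is known for it (the limit of > 5000 nM in this assay, at which 1 of the 3 values shown sits). The two compounds with carbon-only aryl rings do give numbers: compound 2 `Cc1cc(C)c(S(=O)(=O)NC2CCN(C3CCN(C)CC3)CC2)c(C)c1` gives 958 nM in this assay, and compound 3 `Cc1cc(C)c(S(=O)(=O)N2CCC(N3CCC(O)CC3)CC2)c(C)c1` gives 106 nM in this assay. Compound 4 `CCc1ccc(S(=O)(=O)N2CCC(N3CCC(C)CC3)CC2)cc1` has not yet been measured in this assay. It differs from compound 1 by 4-ethylphenyl in place of 2-fluoropyridin-3-yl on a sulfonyl sulfur. Going by the values given here, no measured step of this kind is known, but the numbers of compound 2 and compound 3 point toward a gain in potency, and the expected step is an at least 10-fold lower number from compound 1 to compound 4 (1.00 log units; beyond the scatter). Compound 4 is estimated at 500 nM, between 120 nM and 2500 nM.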

Compound 4, half-maximal inhibitory concentration: > 5000 nM
Compound 4: only a limit was reported; the forecaster's own chance of this, stated with the estimate: 12%; middle value at least 10-fold (1.00 log units) away from the limit.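

Compound 1 and compound 4 both rest at a limit in this assay, so no step can be read between them: the limit of > 5000 nM in this assay, at which 2 of the 4 values shown sit.

The compounds shown leave open whether 4-ethylphenyl in place of 2-fluoropyridin-3-yl on a sulfonyl sulfur changes potency at all in this assay.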